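A few compounds are considered here, and "the series" means these few. Any claim that something is new, unique, unknown or untested is made for them only; others in the source may bear on it.

For the measured compounds named here, compound 1 `Cc1nc(N)sc1CCCN/C(N)=N/C(=O)NC(C)c1ccc(Br)cc1` is one of two compounds so far measured in a functional assay on Right cardiac atrium for agonist activity at histamine H2 receptor (Cavia porcellus), with a stated time of 30 min, in the presence of a further agent that is not named here (a lower number here means a smaller maximal response, a higher number a larger maximal response), where compound 1 gives 0.87. The other is compound 2 `CCCCCCNC(=O)/N=C(\N)NCCCc1sc(N)nc1C`, which in this assay gives 0.95; the two numbers lie within the scatter of each other, so neither can be set apart from the other on this read-out. Going by the values given here, no pair of measured compounds differing in a single place is available, so the series gives no measured step to lean on.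

Compound 3 `Cc1nc(N)sc1CCCN/C(N)=N/C(=O)NC(C)c1ccc(F)cc1` differs from compound 1 in one place: fluoro in place of bromo on an aromatic carbon. Both halogens sit on the same aromatic carbon of the ring, and nothing else in the molecule changes. With both measured compounds near full response, the step from compound 1 to compound 3 is expected to be a number 0.010 higher from compound 1 to compound 3 (within the scatter), that is, nothing beyond the scatter in either direction. Compound 3 is therefore estimated at 0.88 in this assay, with a range from 0.75 to 1.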

Compound 3, intrinsic activity: the largest response reached, as a fraction of the reference agonist's: 0.92
Estimate against measurement, compound 3: 0.040 below, and the stated range covers the measured number.
By their numbers in this assay, from the lowest: compounds 1, 3 and 2 (each within the scatter of the next).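

In this assay the exchange of bromo for fluoro on the aromatic carbon para to a large group reads as a number 0.050 higher from compound 1 to compound 3 (within the scatter) and gives the series its first measured step. At this position, the two halogens cannot be set apart on maximal response, so the read-out stays unchanged within the scatter across this one exchange. No measurement of any property of the two groups is at hand to set beside this step.

As far as these compounds go, whether a group other than a halogen on the same carbon, such as a methoxy group, an amine or a carboxylic acid, would leave the maximal response in place remains open. A single pair also leaves open whether the same exchange would read the same way on another core.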